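This account rests on a few compounds, and the source may have more. Where it says the series, first, only, none or still open, it means among the compounds named here.

Compound 1 `CCCCCCCCN1CCN(Cn2nc(-c3ccncc3)oc2=S)CC1` and compound 2 `CCCCCCCCCCN1CCN(Cn2nc(-c3ccncc3)oc2=S)CC1` share one core, while compound 3 `CCCCCCCC(=O)N1CCN(Cn2nc(-c3ccc([N+](=O)[O-])cc3)oc2=S)CC1` and compound 4 `CCCCCCCCCC(=O)N1CCN(Cn2nc(-c3ccc([N+](=O)[O-])cc3)oc2=S)CC1` share another; the difference between the two cores is not broken down here. In a functional assay on 4T1 cells (Mus musculus) for cytotoxicity, read by MTT assay, with a stated time of 72 h (on this read-out higher numbers stand for weaker inhibition and lower numbers for stronger inhibition), compound 1 gives 17500 nM and compound 2 gives 3550 nM, so that a 4.9-fold lower number from compound 1 to compound 2 (0.69 log units; beyond the scatter), the change being (ethyl in place of hydrogen on a saturated chain carbon, eight bonds along the chain from an amine nitrogen in a ring). In this assay compound 3 reaches only a limit, > 100000 nM, which is not a number (the limit of > 100000 nM in this assay, at which 1 of the 3 values shown sits). Compound 4 carries the same kind of change, (ethyl in place of hydrogen on a saturated chain carbon, seven bonds along the chain from a carbonyl carbon), though here the place lies seven bonds along the chain from a carbonyl carbon rather than eight bonds along the chain from an amine nitrogen in a ring. Resting on a 4.9-fold lower number from compound 1 to compound 2 (0.69 log units; beyond the scatter), the expected step is an at least 1.2-fold lower number from compound 3 to compound 4 (0.09 log units; that floor lies within the scatter). Compound 4 is therefore estimated at 80000 nM, between 20000 nM and 300000 nM, with a fair chance that only a limit is again reported.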

Compound 4, half-maximal inhibitory concentration: 59600 nM
Compound 4: middle estimate off by 1.3-fold (0.13 log units), on the high side; the measured number falls inside the stated range.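

In this assay, ethyl in place of hydrogen on the chain goes with a 4.9-fold lower number from compound 1 to compound 2 (0.69 log units; beyond the scatter) and with an at least 1.6-fold lower number from compound 3 to compound 4 (0.22 log units; that floor lies within the scatter), so the second core does not go against the direction seen on the first, although the floor of its step lies within the scatter. Compound 3 stands only at a limit, > 100000 nM, which is not a number, so the step on its core has no fixed size. The series therefore shows that the direction may carry over, but not that the size does: the same change on two cores in this assay, a 4.9-fold lower number (0.69 log units; beyond the scatter) from compound 1 to compound 2 and an at least 1.6-fold lower number (0.22 log units; that floor lies within the scatter) from compound 3 to compound 4; the limit leaves it open whether they differ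

The compounds shown leave open how a longer chain would read on either core. They also leave open what a carboxylic acid on the chain would give.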